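Aryl hydrazone variation on the diaryl ether urea series

The compounds below may be only part of what the source reports. "The series", "measured", "known", "first", "only" and "open" are said of these compounds alone.

Compound 2 `CN(C)CCn1cnnc1-c1cc(Oc2ccc(NC(=O)N/N=C/c3c[nH]c4ccccc34)cc2F)ccn1` stands second highest of the three numbers in a functional assay on A549 cells (Homo sapiens) for cytotoxicity, read by MTT assay, with a stated time of 72 h (on this read-out lower numbers stand for stronger inhibition and higher numbers for weaker inhibition), where compound 2 gives 820 nM. Compound 1 `CN(C)CCn1cnnc1-c1cc(Oc2ccc(NC(=O)N/N=C/c3ccc(Cl)cc3Cl)cc2F)ccn1` gives 810 nM, and the step of a 1.0-fold higher number from compound 1 to compound 2 (0.01 log units; within the scatter) leaves the two indistinguishable. Compound 3 `CN(C)CCn1cnnc1-c1cc(Oc2ccc(NC(=O)N/N=C/c3ccccc3)cc2F)ccn1` gives 1860 nM; the steps of a 2.3-fold higher number from compound 1 to compound 3 (0.36 log units; beyond the scatter) and a 2.3-fold higher number from compound 2 to compound 3 (0.36 log units; beyond the scatter) are the only ones beyond the scatter, both towards weaker inhibition. Compound 4 `CN(C)CCn1cnnc1-c1cc(Oc2ccc(NC(=O)N/N=C/c3ccc(F)cc3)cc2F)ccn1` carries the change (4-fluorophenyl in place of 1H-indol-3-yl on a carbon with a double bond to nitrogen). The step that bears on it most directly is a 2.3-fold higher number from compound 2 to compound 3 (0.36 log units; beyond the scatter), which also removes the 1H-indol-3-yl; the step of a 2.3-fold higher number from compound 1 to compound 3 (0.36 log units; beyond the scatter) shows the plain phenyl sitting above the 2,4-dichlorophenyl as well. The 4-fluorophenyl falls between those two aryl groups, so a modest rise is expected for compound 4 in this assay, roughly a 1.6-fold higher number from compound 2 to compound 4 (0.20 log units; within the scatter). Compound 4 is accordingly estimated at 1300 nM, with a range from 650 nM to 2600 nM.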

Compound 4, half-maximal inhibitory concentration: 1790 nM
Estimate against measurement, compound 4: 1.4-fold (0.14 log units) below; low and high end bracket the measured number.
By their numbers in this assay, from the lowest: compounds 1 and 2 (each within the scatter of the next); then compounds 4 and 3 (each within the scatter of the next).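

In this assay, the 4-fluorophenyl on a carbon with a double bond to nitrogen does not reach the level of the two larger aryl groups: the steps of a 2.2-fold higher number from compound 2 to compound 4 (0.34 log units; beyond the scatter) and a 2.2-fold higher number from compound 1 to compound 4 (0.34 log units; beyond the scatter) both run towards weaker inhibition. Fluoro in place of hydrogen on an aromatic carbon leaves no readable change, with a 1.0-fold lower number from compound 3 to compound 4 (0.02 log units; within the scatter), so this single fluoro does not lift the plain phenyl towards the level shared by compound 1 and compound 2. Nothing available explains the separation of these two levels.

Open, from the compounds shown here alone, is whether one chlorine on the phenyl ring is enough to reach the level of compound 1, or whether both chlorines of the 2,4-dichlorophenyl are needed. Also open, going by these compounds, is whether a benzofuranyl, with oxygen in place of the indole nitrogen, would stay level with compound 2.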